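Removing the Carbamate From an Isoindolinone Amide

The compounds below may be only part of what the source reports. "The series", "measured", "known", "first", "only" and "open" are said of these compounds alone.

Compound 2 `CC(C)(C)OC(=O)N(Cc1ccco1)C(=O)c1ccc(CN2Cc3ccccc3C2=O)cc1` carries a tert-butoxycarbonyl group on its amide nitrogen, and in an ADME assay on RAW264.7 cells (Mus musculus) for cytotoxicity, read by WST assay (a higher number here means that more compound is tolerated, a lower number that less compound is tolerated), compound 2 gives 95200 nM. Compound 1 `O=C(c1ccc(CN2Cc3ccccc3C2=O)cc1)N1CCCCC1` shares the same core but ends in a piperidine amide; in this assay compound 1 reaches only a limit of the assay, > 100000 nM, rather than a number. Among the two results shown, compound 2 thus holds the only measured number, while the other result sits at the limit of > 100000 nM in this assay, at which 1 of the 2 values shown sits.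

Compound 3 `O=C(NCc1ccco1)c1ccc(CN2Cc3ccccc3C2=O)cc1` has not yet been measured. It differs from compound 2 by hydrogen in place of tert-butoxycarbonyl on an amide-type nitrogen. Within the data shown here, no measured pair shows this change, so its size is not known from the data. Since compound 2 already sits close to the top of what the assay reports, the step from compound 2 to compound 3 is expected to be small, at most a modest rise toward the limit, a 1.3-fold higher number from compound 2 to compound 3 (0.10 log units; within the scatter). Compound 3 is therefore estimated at 120000 nM, with a range from 60000 nM to 250000 nM, and a fair chance that only a limit is reported.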

Compound 3, concentration lethal to 50% of the cells: > 100000 nM
Compound 3 was reported as a limit (the forecaster's own chance of this, stated with the estimate: 60%); the middle value is on the limit's open side.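

Among these compounds, the tert-butoxycarbonyl group was the only thing that set compound 2 apart from compound 3, and putting hydrogen in its place on the amide-type nitrogen gives an at least 1.0-fold higher number from compound 2 to compound 3 (0.02 log units; that floor lies within the scatter). Among the compounds shown here, this is the first direct reading of this change in this assay, and it shows no loss of tolerance when the seven heavy atoms of the carbamate group leave, although the true size of the step stays hidden because compound 3 gives only a limit, > 100000 nM. The two compounds without the tert-butoxycarbonyl group, compound 1 and compound 3, end at the same limit: the limit of > 100000 nM in this assay, at which 2 of the 3 values shown sit.

The step between compound 1 and compound 3 cannot be read, as both results are limits, so the exchange of piperidin-1-yl for ((furan-2-yl)methyl)amino on the carbonyl carbon has no measured size. Still open, on these data alone, is whether an acetyl group, a methyl group or a longer chain in place of hydrogen on this amide-type nitrogen would give a real number in this assay rather than a limit, and so show how much this nitrogen's substituent matters.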